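Replacing 2-phenylethynyl with 4-methoxyphenyl on the shared core

This account rests on a few compounds, and the source may have more. Where it says the series, first, only, none or still open, it means among the compounds named here.

Among the compounds with values here, in a functional assay on HCT-116 cells (Homo sapiens) for antiproliferative activity, with a stated time of 72 h (a lower number here means a stronger inhibitor, a higher number a weaker inhibitor), compound 1 `Nc1ncnn2c([C@@H]3O[C@H](CO)[C@@H](O)[C@H]3O)cc(C#Cc3cccs3)c12` gives 65500 nM and compound 2 `Nc1ncnn2c([C@@H]3O[C@H](CO)[C@@H](O)[C@H]3O)cc(C#Cc3ccccc3)c12` gives 46900 nM, so compound 2 stands within the scatter of its only measured neighbour. Compound 3 `COc1ccc(-c2cc([C@@H]3O[C@H](CO)[C@@H](O)[C@H]3O)n3ncnc(N)c23)cc1` differs from compound 2 by 4-methoxyphenyl in place of 2-phenylethynyl on an aromatic carbon, with 4-methoxyphenyl in place of 2-phenylethynyl on an aromatic carbon. Within the data shown here, the one measured step, a 1.4-fold lower number from compound 1 to compound 2 (0.15 log units; within the scatter), keeps the triple bond, so it bears only indirectly on this change and offers no sign of a large effect. The expected result is a 1.3-fold lower number from compound 2 to compound 3 (0.13 log units; within the scatter), with no change beyond the scatter anticipated. For compound 3 the estimate is 35000 nM, with an expected range from 6000 nM to 100000 nM.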

Compound 3, half-maximal inhibitory concentration: 47100 nM
The estimate for compound 3 lay 1.3-fold (0.13 log units) below the measured number; the range from low to high includes it.
By their numbers in this assay, from the lowest: compounds 2, 3 and 1 (each within the scatter of the next).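

In this assay the triple bond proves dispensable at this aromatic carbon: 4-methoxyphenyl in place of 2-phenylethynyl gives a 1.0-fold higher number from compound 2 to compound 3 (0.00 log units; within the scatter) and in place of 2-(thiophen-2-yl)ethynyl gives a 1.4-fold lower number from compound 1 to compound 3 (0.14 log units; within the scatter) with the same outcome. Removing the triple bond and adding a hydrogen-bond acceptor, at an unchanged heavy-atom count, thus leaves the number within the scatter. Nothing available explains this result. Going by these compounds, all three compounds carry an aromatic ring here, so the effect of an amine, a carboxylic acid or a longer chain at this carbon remains open.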